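The compounds below may be only part of what the source reports. "The series", "measured", "known", "first", "only" and "open" are said of these compounds alone.

Measured compounds:

Compound 1, `CCC1=C(O)c2c(oc(-c3ccc(C)cc3C)cc2=O)C(CC)(CC)C1=O`, 41.2 uM
Compound 2, `CCC1=C(O)c2c(oc(-c3ccc(OC)c(C)c3C)cc2=O)C(CC)(CC)C1=O`, 5.43 uM
Compound 3, `CCC1=C(O)c2c(oc(-c3cc(OC)ccc3OC)cc2=O)C(CC)(CC)C1=O`, 8.8 uM

These three compounds share one core and differ only in the aromatic group attached next to the ring oxygen. In a functional assay on KB cells (Homo sapiens) for antiproliferative activity, read by sulforhodamine B assay, with a stated time of 3 days (on this read-out lower numbers stand for an effect already at smaller amounts and higher numbers for an effect only at larger amounts of compound), compound 1 gives 41.2 uM, the highest number of the three; compound 3 sits nearest, and compound 2 is furthest away, both gaps lying beyond the scatter. Compound 4, `CCC1=C(O)c2c(oc(-c3cc(C)ccc3F)cc2=O)C(CC)(CC)C1=O`, has not yet been measured. Compared with compound 1, it carries 2-fluoro-5-methylphenyl in place of 2,4-dimethylphenyl on an aromatic carbon. Within the data shown here, no measured pair shows exactly this kind of exchange, so the size of the step must be guessed from the spread of the three numbers, which shows that a change of small groups on this aromatic ring can move the result well beyond the scatter. For compound 4 a modest step toward a lower number is expected, a 2.1-fold lower number from compound 1 to compound 4 (0.31 log units; beyond the scatter), though a result within the scatter of compound 1 cannot be ruled out. The estimate for compound 4 is 20 uM, with a range from 6 uM to 60 uM.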

Compound 4, concentration for half-maximal effect: 47.3 uM
For compound 4 the middle estimate is 2.4-fold (0.37 log units) below the measured one, within the range that was stated.
By their numbers in this assay, from the lowest: compounds 2 and 3 (each within the scatter of the next); then compounds 1 and 4 (each within the scatter of the next).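

In this assay, putting 2-fluoro-5-methylphenyl in place of 2,4-dimethylphenyl gives a 1.1-fold higher number from compound 1 to compound 4 (0.06 log units; within the scatter), so this exchange on the aromatic carbon of the shared core leaves the result unchanged within the usual scatter. Among these compounds, the earlier compounds showed only that the aromatic group can matter; this pair shows that not every change to it does, even one that brings in a fluorine and rearranges the small groups on the ring. Nothing at hand explains why these two groups give such similar results.

Among the compounds shown here, it remains open whether the methoxy groups of compound 2 and compound 3 go with their lower numbers, as no pair here changes that group alone. Also open, going by these compounds, is how an amine or a carboxylic acid on this aromatic ring would behave in this assay.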